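The source may hold more compounds than are shown below. What is called first, only, known or untested is meant among the compounds shown, and "the series" means these compounds.

Three close relatives share one core, and each has been tested in a functional assay on BT-483 cells (Homo sapiens) for cytotoxicity, read by MTT assay, with a stated time of 24 h; on this read-out higher numbers stand for weaker inhibition and lower numbers for stronger inhibition. Compound 1, `CCNc1cc(-c2ccc(NC(=O)Nc3ccc(OC)cc3)cc2C)ccn1`, gives 25800 nM. Compound 2, `CCNc1cc(-c2ccc(NC(=O)Nc3ccc(C(F)(F)F)cc3)cc2C)ccn1`, gives 19700 nM. Compound 3, `CCNc1cc(-c2ccc(NC(=O)Nc3ccc(OC)cc3)cc2C(F)(F)F)ccn1`, gives 17600 nM. Two single changes connect them. From compound 1 to compound 2 the change is trifluoromethyl in place of methoxy on an aromatic carbon, and the step is a 1.3-fold lower number from compound 1 to compound 2 (0.12 log units; within the scatter). From compound 1 to compound 3 the change is trifluoromethyl in place of methyl on an aromatic carbon, and the step is a 1.5-fold lower number from compound 1 to compound 3 (0.17 log units; within the scatter). All three numbers thus sit close together.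

Compound 4, `CCNc1cc(-c2ccc(NC(=O)Nc3ccc(C(F)(F)F)cc3)cc2C(F)(F)F)ccn1`, has not yet been measured in this assay. It differs from compound 3 by trifluoromethyl in place of methoxy on an aromatic carbon. This is the same change already seen from compound 1 to compound 2, where it gave a 1.3-fold lower number from compound 1 to compound 2 (0.12 log units; within the scatter); the two cores on which it is made differ by trifluoromethyl in place of methyl on an aromatic carbon, while the place of the change reads the same in both cases.

Going by the values given here, for compound 4 the step from compound 3 is expected to be a 1.3-fold lower number from compound 3 to compound 4 (0.10 log units; within the scatter), resting on the one earlier instance of this change, which gave a 1.3-fold lower number from compound 1 to compound 2 (0.12 log units; within the scatter). Compound 4 is therefore estimated at 14000 nM, expected to fall between 7000 nM and 28000 nM.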

Compound 4, half-maximal inhibitory concentration: 16400 nM
For compound 4 the middle estimate is 1.2-fold (0.07 log units) below the measured one; low and high end bracket the measured number.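

In this assay the change of methoxy to trifluoromethyl gives a 1.1-fold lower number from compound 3 to compound 4 (0.03 log units; within the scatter), which agrees with its earlier instance: the same change on two cores in this assay, a 1.3-fold lower number (0.12 log units; within the scatter) from compound 1 to compound 2 and a 1.1-fold lower number (0.03 log units; within the scatter) from compound 3 to compound 4, 1.2-fold (0.09 log units) apart, within the scatter of two such steps. The change of methyl to trifluoromethyl gives a 1.2-fold lower number from compound 2 to compound 4 (0.08 log units; within the scatter), and it also agrees with its earlier instance: the same change on two cores in this assay, a 1.5-fold lower number (0.17 log units; within the scatter) from compound 1 to compound 3 and a 1.2-fold lower number (0.08 log units; within the scatter) from compound 2 to compound 4, 1.2-fold (0.09 log units) apart, within the scatter of two such steps. Each change therefore reads the same on the two cores shown, but all of these steps are so small that the agreement shows only that neither change moved the number beyond the scatter, not that either has a real effect that carries over to further cores.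

The compounds shown carry only methoxy or trifluoromethyl at the place para to a large group, and only methyl or trifluoromethyl at the other changed place. On these data alone, it remains open how a different group at either place, such as an amine, a carboxylic acid or a longer chain, would read in this assay.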